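The compounds below may be only part of what the source reports. "The series", "measured", "known", "first", "only" and "open" are said of these compounds alone.

Of the compounds shown here, two of a shared core have been tested so far in a functional assay on SK-BR-3 cells (Homo sapiens) for inhibition; on this read-out lower numbers stand for stronger inhibition and higher numbers for weaker inhibition. Compound 1, with the structure `COc1c(C)cnc(CN2CC(=O)N(C(C)C(=O)NCCN(C)C)c3c(Cl)nc(N)nc32)c1C`, gives 30 nM in this assay. Compound 2, with the structure `COc1c(C)cnc(CN2CC(OC3CCCC3)=Nc3c(Cl)nc(N)nc32)c1C`, gives 5 nM in this assay. Among the measured compounds shown here, of these two numbers the one for compound 1 is the higher, so compound 1 is the weaker inhibitor of the pair, and the gap between compound 1 and compound 2 lies beyond the usual scatter of repeated measurements.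

Compound 3, with the structure `COc1c(C)cnc(CN2CC(=O)N(CCN3CCCC3)c3c(Cl)nc(N)nc32)c1C`, has not yet been measured in this assay. It differs from compound 1 in one place: 2-(pyrrolidin-1-yl)ethyl in place of 1-((2-(dimethylamino)ethyl)carbamoyl)ethyl on an amide-type nitrogen in a ring. The group that leaves and the group that enters both carry a basic-looking nitrogen at the end of a short chain, but the amide link and its hydrogen-bond donor are gone in compound 3.

For the measured compounds named here, no measured step connects compound 1 to compound 3, so the expectation rests on compound 1 alone. The step of a 1.5-fold lower number from compound 1 to compound 3 (0.18 log units; within the scatter) is expected to be small, within the usual scatter. Compound 3 is therefore expected to give about 20 nM in this assay, within a range from 5 nM to 80 nM.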

Compound 3, half-maximal inhibitory concentration: 300 nM
Compound 3: middle estimate off by 15-fold (1.18 log units), on the low side; the measured number lies above the stated range.
By their numbers in this assay, from the lowest: compound 2; then compound 1; then compound 3.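

The nitrogen position is sensitive to what it carries. In this assay, replacing 1-((2-(dimethylamino)ethyl)carbamoyl)ethyl with 2-(pyrrolidin-1-yl)ethyl gives a 10-fold higher number from compound 1 to compound 3 (1.00 log units; beyond the scatter) as a step beyond the usual scatter, so the weakening is a real difference between these two compounds. Both groups end in an amine on a short chain, so in this one pair, an amine-bearing chain at this position is not enough to keep the inhibition seen with compound 1, and nothing available here explains the loss of inhibition.

The single change alters several features at once: the group loses its carbamoyl link, including its 1 hydrogen-bond donor, drops from 10 heavy atoms to 7, and gains a five-membered ring, and the compounds shown cannot tell which of these features matters. A 2-(dimethylamino)ethyl group at this position, which has the open-chain amine but no carbamoyl link, would help to separate the effect of losing that link from the effect of adding the ring, while a 1-carbamoylethyl group, with the link but no amine, would show whether the amine is needed at all.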